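The compounds below may be only part of what the source reports. "The series", "measured", "known", "first", "only" and "open" are said of these compounds alone.

Compound 1 `CN(C)c1ncnc2c(Cc3ccccc3)ncn12` and compound 2 `Cc1ccc(Cc2ncn3c(N(C)C)ncnc23)cc1` share one core, while compound 3 `Cc1ncn2c(=O)[nH]c(=S)[nH]c12` and compound 4 `Cc1nc(C)n2c(=O)[nH]c(=S)[nH]c12` share another; the difference between the two cores is not broken down here. In a functional assay on CCRF-CEM cells (Homo sapiens) for cytotoxicity (on this read-out lower numbers stand for higher toxicity in this test and higher numbers for lower toxicity in this test), compound 1 reaches only a limit, > 790000 nM, the same limit as the limit of > 790000 nM in this assay, at which 1 of the 3 values shown sits. In this assay compound 2 gives 412000 nM and compound 3 gives 786000 nM. The change methyl in place of hydrogen on an aromatic carbon brought an at least 1.9-fold lower number from compound 1 to compound 2 (0.28 log units; that floor lies within the scatter). Compound 4 carries the same kind of change, (methyl in place of hydrogen on an aromatic carbon), though on a five-membered aromatic ring with 2 nitrogen, between two ring nitrogen atoms, rather than on a six-membered aromatic ring of carbon only, para to a large group. Since the earlier step rests on a limit and its floor lies within the scatter, compound 4 is expected to show only a 1.3-fold lower number from compound 3 to compound 4 (0.12 log units; within the scatter) in this assay. Compound 4 is therefore estimated at 600000 nM, within 250000 nM and 1500000 nM.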

Compound 4, half-maximal cytotoxic concentration: 526000 nM
The estimate for compound 4 lay 1.1-fold (0.06 log units) above the measured number, and the stated range covers the measured number.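

Putting a methyl in place of hydrogen on an aromatic carbon of the core shared by compound 3 and compound 4 gives a 1.5-fold lower number from compound 3 to compound 4 (0.17 log units; within the scatter) in this assay, so on this core the change shows no clear effect. The comparison with the other core stays loose: the same change on two cores in this assay, an at least 1.9-fold lower number (0.28 log units; that floor lies within the scatter) from compound 1 to compound 2 and a 1.5-fold lower number (0.17 log units; within the scatter) from compound 3 to compound 4; the limit leaves it open whether they differ. The two steps therefore show neither that the change carries over from one core to the other with the same size nor that it does not.

Still open, from the compounds shown here alone, is whether a larger group at this place between two ring nitrogen atoms, such as an ethyl, or a different one, such as an amine or a carboxylic acid, would shift the number beyond the scatter.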